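A few compounds are considered here, and "the series" means these few. Any claim that something is new, unique, unknown or untested is made for them only; others in the source may bear on it.

Working notes on the benzimidazole-acetic acid series, the shared core being visible in compound 1 `O=C(O)Cn1c(SCCNc2ccccc2)nc2ccccc21`. In an assay on HEK293 cells for displacement of a labelled ligand from prostaglandin D2 receptor 2 (Homo sapiens) (a lower number here means a stronger inhibitor, a higher number a weaker inhibitor), compound 1 gives 7690 nM. Compound 2 `O=C(O)Cn1c(SCc2ccccc2Cl)nc2ccccc21` gives 370 nM in this assay, and compound 3 `O=C(O)Cn1c(SCc2cc(Cl)ccc2Cl)nc2ccccc21` gives 470 nM. Compound 3 thus stands second highest of the three numbers; its nearest neighbour is compound 2, with a 1.3-fold higher number from compound 2 to compound 3 (0.10 log units; within the scatter), while compound 1 lies far above it, beyond the scatter.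

The next member, compound 4 `COc1ccc(Cl)cc1CSc1nc2ccccc2n1CC(=O)O`, differs from compound 3 by methoxy in place of chloro on an aromatic carbon. Going by the values given here, no measured pair exchanges a chloro for a methoxy, so no step bears on this change directly. Among the compounds with values here, the only step on the same ring, the addition of a chloro para to the existing one from compound 2 to compound 3, stayed within the scatter, and the ring substitution pattern of compound 4 keeps that para chloro. A step of no more than scatter size in this assay is therefore expected, in no clear direction, with the expected change being a 1.1-fold higher number from compound 3 to compound 4 (0.03 log units; within the scatter). Compound 4 is estimated at 500 nM, within a range of 180 nM to 1500 nM.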

Compound 4, half-maximal inhibitory concentration: 740 nM
The estimate for compound 4 lay 1.5-fold (0.17 log units) below the measured number; the measured number falls inside the stated range.
By their numbers in this assay, from the lowest: compounds 2, 3 and 4 (each within the scatter of the next); then compound 1.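

Methoxy in place of chloro, on the aromatic carbon ortho to a large group and para to a chloro group, gives a result in this assay that stays within the scatter (a 1.6-fold higher number from compound 3 to compound 4 (0.20 log units; within the scatter)). The earlier step concerned only the added chloro group on this ring, whereas this one exchanges the group at the ortho position, and one more heavy atom and a hydrogen-bond acceptor there leave the number within the scatter of compound 3. No available evidence bears on the reason for this reading.

The compounds shown leave open whether an amine, a hydroxyl or a longer ether chain such as ethoxy at this position would also stay within the scatter. They also leave open how methoxy reads at this position when the chloro group para to it is replaced by hydrogen.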